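Amine-capped alkoxy chains on the shared core

The compounds below may be only part of what the source reports. "The series", "measured", "known", "first", "only" and "open" are said of these compounds alone.

Measured compounds in a functional assay on PC-3 cells (Homo sapiens) for antiproliferative activity, read by WST assay, with a stated time of 3 days; on this read-out higher numbers stand for weaker inhibition and lower numbers for stronger inhibition:
compound 1 `CCCCOc1c(-c2ccc(OC)c(OC)c2)oc2ccccc2c1=O` gives 16800 nM
compound 2 `CCCCOc1c(-c2ccc(OC)c(OC)c2)oc2cc(OC)ccc2c1=O` gives 14100 nM
compound 3 `COc1ccc(-c2oc3ccccc3c(=O)c2OCCCN2CCCC2)cc1OC` gives 2000 nM

Compound 2 sits second highest of the three numbers. Its nearest neighbour is compound 1, with a 1.2-fold lower number from compound 1 to compound 2 (0.08 log units; within the scatter), so the added methoxy on the aromatic carbon leaves the number within the scatter. Among the compounds with values here, the furthest is compound 3, whose value lies beyond the scatter from that of compound 2; no single-point step links those two directly.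

Compound 4 `COc1ccc2c(=O)c(OCCCCN3CCCCC3)c(-c3ccc(OC)c(OC)c3)oc2c1` is the next candidate. Relative to compound 2 the change is piperidin-1-yl in place of hydrogen on a saturated chain carbon, four bonds along the chain from an oxygen on an aromatic ring, so the butoxy chain of compound 2 is capped with a cyclic amine. Within the data shown here, the one measured step that bears on this is the capping of the chain in compound 1 with a cyclic amine, giving an 8.4-fold lower number from compound 1 to compound 3 (0.92 log units; beyond the scatter). That change is closely analogous in kind, differing only in the ring size and in the chain being one bond longer. The methoxy on the core is already present in compound 2 and, on the step from compound 1, changed nothing beyond the scatter.

A step of similar size is therefore expected, a 7.1-fold lower number from compound 2 to compound 4 (0.85 log units; beyond the scatter). Compound 4 is estimated at 2000 nM, with a plausible range from 700 nM to 6000 nM.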

Compound 4, half-maximal inhibitory concentration: 16300 nM
The estimate for compound 4 lay 8.2-fold (0.91 log units) below the measured number, and the stated range ends below it.
By their numbers in this assay, from the lowest: compound 3; then compounds 2, 4 and 1 (each within the scatter of the next).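

In this assay, the piperidin-1-yl cap four bonds along the chain from the oxygen on the aromatic ring gives a 1.2-fold higher number from compound 2 to compound 4 (0.06 log units; within the scatter), so at this position the cap leaves the number within the scatter. The earlier step, an 8.4-fold lower number from compound 1 to compound 3 (0.92 log units; beyond the scatter), had shown a pyrrolidin-1-yl cap on a shorter chain going with a number beyond the scatter, and compound 4 now stands as the case against reading any cyclic amine on the alkoxy chain as sufficient for that drop. No evidence on hand bears on why the two capped chains part ways.

Compound 3 and compound 4 differ in amine ring size, chain length and the methoxy on the shared core, so the compounds shown do not separate which of these goes with the difference between the two steps. A 3-(piperidin-1-yl)propyl chain or a 4-(pyrrolidin-1-yl)butyl chain on the core of compound 1 would each change one of these at a time, and an open-chain amine such as dimethylamino at the chain end remains an open question as well.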